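The source may hold more compounds than are shown below. What is called first, only, known or untested is meant among the compounds shown, and "the series" means these compounds.

In a functional assay on HT-29 cells (Homo sapiens) for inhibition, read by sulforhodamine B assay, with a stated time of 48 h (on this read-out higher numbers stand for weaker inhibition of growth and lower numbers for stronger inhibition of growth), compound 1 `CC1=CC[C@H](C(C)(C)NC(=S)N/N=C/c2ccccc2)CC1` gives 22200 nM, the lowest of the two plain numbers shown. Compound 3 `CC1=CC[C@H](C(C)(C)NC(=S)N/N=C/c2cccc(Cl)c2)CC1` gives 53000 nM, so there was a 2.4-fold higher number from compound 1 to compound 3 (0.38 log units; beyond the scatter). Compound 2 `CC1=CC[C@H](C(C)(C)NC(=S)N/N=C/c2ccc(N(C)C)cc2)CC1` gives > 100000 nM in this assay, which is a limit of the assay rather than a number, namely (the limit of > 100000 nM in this assay, at which 1 of the 3 values shown sits). Read that way, there was an at least 4.5-fold higher number from compound 1 to compound 2 (0.65 log units; beyond the scatter). Compound 4 `CC1=CC[C@H](C(C)(C)NC(=S)N/N=C/c2ccccc2[N+](=O)[O-])CC1` has not yet been measured; it differs from compound 1 by nitro in place of hydrogen on an aromatic carbon. Both changes measured on that same ring raised the number, so a weaker result for compound 4 is expected, with an estimated step in this assay of a 2.0-fold higher number from compound 1 to compound 4 (0.31 log units; beyond the scatter). The value expected for compound 4 in this assay is 45000 nM, estimated to lie between 18000 nM and 110000 nM.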

Compound 4, concentration for total growth inhibition: 70800 nM
Compound 4: the middle estimate sits 1.6-fold (0.20 log units) below what was measured; the range from low to high includes it.
By their numbers in this assay, from the lowest: compound 1; then compounds 3 and 4 (each within the scatter of the next). At a limit, above all of these: compound 2.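

Nitro, ortho to a large group, is the only change shown at this position, and it also weakens growth inhibition in this assay, with a 3.2-fold higher number from compound 1 to compound 4 (0.50 log units; beyond the scatter). Each group shown on this ring, in compounds 2, 3 and 4, therefore gives a higher number than the unsubstituted ring of compound 1, and no compound shown goes against this. Nothing given here explains the step at this position.

From the compounds shown here alone, whether methyl, fluoro or an amine at this same position would also raise the number remains open. So does the step that nitro would give elsewhere on the ring.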